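From nitro to methoxy: compound 2 to compound 4

A few compounds are considered here, and "the series" means these few. Any claim that something is new, unique, unknown or untested is made for them only; others in the source may bear on it.

Measured in an ADME assay on Raji cells (Homo sapiens) for cytotoxicity, with a stated time of 72 h; on this read-out higher numbers stand for an effect only at larger amounts of compound and lower numbers for an effect already at smaller amounts:
- compound 1 `Cc1cc(NC(=O)Nc2ccc(Cl)c(Cl)c2)c2ccccc2n1`: 10000 nM
- compound 2 `Cc1cc(NC(=O)Nc2cccc([N+](=O)[O-])c2)c2ccccc2n1`: > 25000 nM (a limit)
- compound 3 `Cc1cc(NC(=O)Nc2ccccc2C(C)(C)C)c2ccccc2n1`: > 25000 nM (a limit)

Compound 2 gives only a limit, > 25000 nM, and not a number. Compound 3 likewise gives a limit, > 25000 nM. Among the measured compounds shown here, the series so far therefore sits largely on (the limit of > 25000 nM in this assay, at which 2 of the 3 values shown sit). For the measured compounds named here, compound 1 is the only one with a true number, 10000 nM. Going by the values given here, no measured pair differs in one place, so the size of a single change cannot be read from the series.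

Compound 4 `COc1cccc(NC(=O)Nc2cc(C)nc3ccccc23)c1` carries methoxy in place of nitro on an aromatic carbon, meta to a large group: methoxy in place of nitro on an aromatic carbon.

In this assay no step beyond the usual scatter is expected, with perhaps a slight move towards lower numbers, since compound 1 gives 10000 nM. The expected change is an at least 1.2-fold lower number from compound 2 to compound 4 (0.09 log units; that floor lies within the scatter). Another limit would fit this expectation. For compound 4 the estimate is 20000 nM, with an expected range of 8000 nM to 30000 nM.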

Compound 4, half-maximal effective concentration: > 25000 nM
Compound 4: a limit, no number (the forecaster's own chance of this, stated with the estimate: 55%); middle value at least 1.2-fold (0.09 log units) from the limit.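

Compound 4 gives > 25000 nM as a limit and not a number. Compound 2 also gives only a limit, so no step can be read from compound 2 to compound 4, and the series stays where it was: the limit of > 25000 nM in this assay, at which 3 of the 4 values shown sit.

In this assay the compounds shown leave open how far methoxy in place of nitro moves the read-out, if at all.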